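Replacing ethoxy with 2-methoxyethyl on a shared core

The source may hold more compounds than are shown below. What is called first, only, known or untested is meant among the compounds shown, and "the series" means these compounds.

In an in vitro ADME assay on microsomes from liver (Homo sapiens) for metabolic stability (on this read-out higher numbers stand for fast clearance and lower numbers for slow clearance), compound 2 `CCOc1nc2nc(C)cc(Nc3ccc(C(F)(F)F)cc3)n2n1` gives 7 mL.min-1.g-1 and compound 1 `COCc1nc2nc(C)cc(Nc3ccc(C(F)(F)F)cc3)n2n1` gives 6.7 mL.min-1.g-1, so the two stand level. Compound 3 `COCCc1nc2nc(C)cc(Nc3ccc(C(F)(F)F)cc3)n2n1` differs from compound 2 in one place, with 2-methoxyethyl in place of ethoxy on an aromatic carbon. Among the compounds with values here, only one measured step bears on this change: a 1.0-fold higher number from compound 1 to compound 2 (0.02 log units; within the scatter), which put ethoxy in place of methoxymethyl at that same carbon. With so little evidence, no shift beyond the scatter is expected, and the estimated step is a 1.1-fold higher number from compound 2 to compound 3 (0.06 log units; within the scatter). The expected value for compound 3 is 8 mL.min-1.g-1, within an estimated range of 4 mL.min-1.g-1 to 16 mL.min-1.g-1.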

Compound 3, intrinsic clearance in microsomes: 9 mL.min-1.g-1
Beside the measured number, compound 3's estimate is 1.1-fold (0.05 log units) below it, within the range that was stated.
By their numbers in this assay, from the lowest: compounds 1, 2 and 3 (each within the scatter of the next).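

Swapping ethoxy for 2-methoxyethyl stays within the usual scatter in this assay (a 1.3-fold higher number from compound 2 to compound 3 (0.11 log units; within the scatter)), and the same holds against the methoxymethyl chain (a 1.3-fold higher number from compound 1 to compound 3 (0.13 log units; within the scatter)). So the earlier pair's level result now extends to a third chain: at this aromatic carbon, ethoxy, methoxymethyl and 2-methoxyethyl cannot be told apart on this read-out. No measurement shown here offers an explanation for this. Still open, as far as these compounds go, is whether an amine, a carboxylic acid or a longer chain at this carbon would move the number beyond the scatter.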